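The compounds below may be only part of what the source reports. "The series", "measured", "known", "first", "only" and "open" are said of these compounds alone.

Going by the values given here, in an in vitro functional assay on HEK285-7 cells for antagonist activity at prostaglandin D2 receptor 2 (Homo sapiens), read by BRET and beta-arrestin recruitment (a higher number here means a larger maximal response, a lower number a smaller maximal response), compound 1 `NS(=O)(=O)c1ccc(-c2nc(C(c3ccc(F)cc3)c3ccc(F)cc3)sc2CC(=O)O)cc1` gives 80%, the higher of the two values measured so far. Among the compounds with values here, compound 2 `Cc1nc(-c2ccc(Cl)cc2)c(CC(=O)O)s1`, the only other measured compound, gives 50% in this assay, a gap beyond the usual scatter, though the two structures differ in several places at once. Compound 3 `O=C(O)Cc1sc(C(c2ccc(F)cc2)c2ccc(F)cc2)nc1-c1ccccc1` differs from compound 1 in one place only: hydrogen in place of sulfamoyl on an aromatic carbon. Within the data shown here, no pair of measured compounds differing in a single place exists, so the size of such a step is not known from the data. Losing the sulfamoyl group is expected to lower the maximal response modestly, giving an expected step of a number 15 percentage points lower from compound 1 to compound 3 (beyond the scatter). Compound 3 is therefore estimated at 65%, within 45% to 85%.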

Compound 3, largest response reached (reported as efficacy), in percent of the reference or control that the assay uses: 80%
For compound 3 the middle estimate is 15 percentage points below the measured one; the range from low to high includes it.
By their numbers in this assay, from the lowest: compound 2; then compounds 1 and 3 (each within the scatter of the next).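

Swapping sulfamoyl for hydrogen gives no change at the digits printed from compound 1 to compound 3 (within the scatter) in this assay, and this is the first single-place step that can be read in the series. On the shared core, at this carbon para to a large group, the 4-sulfamoylphenyl can therefore be reduced to phenyl with no change in maximal response beyond the scatter. Still open, going by these compounds, is whether an amine or a carboxylic acid at the same carbon would leave the response equally unchanged. No measurement at hand accounts for this result.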